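The source may report more compounds than this note shows. Statements on the series, on what has been measured and on what is new or still open speak of the compounds shown alone.

Within the data shown here, in an ADME assay on CCRF-HSB-2 cells (Homo sapiens) for cytotoxicity, with a stated time of 7 days (on this read-out higher numbers stand for lower toxicity in this test and lower numbers for higher toxicity in this test), compound 1 `CCCCCCSc1nc(N)nc2c1ncn2/C=C1/CC1(CO)CO` gives 60000 nM and compound 2 `CC(C)Sc1nc(N)nc2c1ncn2/C=C1/CC1(CO)CO` gives 94000 nM, so compound 2 stands within the scatter of the only other measured compound. The next analogue, compound 3 `CCCCOc1nc(N)nc2c1ncn2/C=C1/CC1(CO)CO`, has butoxy in place of isopropylsulfanyl on an aromatic carbon, next to the ring nitrogen: butoxy in place of isopropylsulfanyl on an aromatic carbon. Among the measured compounds shown here, only one measured step bears on this change: a 1.6-fold higher number from compound 1 to compound 2 (0.19 log units; within the scatter), with isopropyl in place of hexyl on a sulfur. For the measured compounds named here, that step concerns the chain on sulfur, and no measured compound carries butoxy, so the exchange itself remains untested. No step beyond the scatter is therefore expected in this assay. The expected step is a 1.3-fold lower number from compound 2 to compound 3 (0.13 log units; within the scatter). For compound 3, the estimated value is 70000 nM, within an expected range of 30000 nM to 140000 nM.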

Compound 3, half-maximal cytotoxic concentration: > 20000 nM
Compound 3 was reported as a limit; the forecaster's own chance of this, stated with the estimate: 30%; the middle value does not contradict the limit.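

Among these compounds, compound 3 is reported in this assay only as a limit, so no step from compound 1 or compound 2 to compound 3 can be read: the limit of > 20000 nM in this assay, at which 1 of the 3 values shown sits. The compounds shown leave open how butoxy compares with isopropylsulfanyl or hexylsulfanyl on the shared core in this assay.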